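The source may hold more compounds than are shown below. What is called first, only, known or untested is meant among the compounds shown, and "the series" means these compounds.

In a functional assay on MDA-MB-231 cells (Homo sapiens), read by microscopy and transwell migration, with a stated time of 24 h (a lower number here means a stronger inhibitor, a higher number a weaker inhibitor), compound 1 (`COc1cc(C(=O)Nc2nc(-c3cc(OC)c(OC)c(OC)c3)cs2)cc(OC)c1OC`) gives 1030 nM, and compound 2 (`COc1cc(-c2csc(N(C)C(=O)c3ccccc3)n2)cc(OC)c1OC`) gives 10000 nM. Compound 3 (`COc1ccc(C(=O)N(C)c2nc(-c3cc(OC)c(OC)c(OC)c3)cs2)cc1OC`) stands at > 25000 nM, which is a limit of the assay and not a number. Compound 4 (`COc1cc(C(=O)N(C)c2nc(-c3cc(OC)c(OC)c(OC)c3)cs2)cc(OC)c1OC`) differs from compound 3 by one change: methoxy in place of hydrogen on an aromatic carbon, with methoxy in place of hydrogen on an aromatic carbon, ortho to a methoxy group and meta to a large group.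

The closest measured step is an at least 2.5-fold higher number from compound 2 to compound 3 (0.39 log units; beyond the scatter), where 3,4-dimethoxyphenyl replaces phenyl on a carbonyl carbon. Adding methoxy groups on that side therefore went with a weaker result, beyond the scatter. Compound 1 points the other way: it carries the same group on its carbonyl as compound 4 and has the amide hydrogen where compound 4 has a methyl group. Compound 1 gives 1030 nM. These two signals leave the direction only loosely fixed, and the starting point in this assay is itself a limit. A modest shift towards a stronger result is expected, described as an at least 1.6-fold lower number from compound 3 to compound 4 (0.22 log units; that floor lies within the scatter), and a reading that again reaches the limit would be no surprise. Compound 4 is estimated at 15000 nM, with an expected range from 4000 nM to 25000 nM.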

Compound 4, half-maximal inhibitory concentration: 470 nM
Compound 4: middle estimate off by 32-fold (1.50 log units), on the high side, and the stated range ends above it.
By their numbers in this assay, from the lowest: compound 4; then compound 1; then compound 2. At a limit, above all of these: compound 3.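

With methoxy in place of hydrogen on an aromatic carbon, ortho to a methoxy group and meta to a large group, this assay shows an at least 53-fold lower number from compound 3 to compound 4 (1.72 log units; beyond the scatter) and so marks this position as highly sensitive to the change, which an at least 2.5-fold higher number from compound 2 to compound 3 (0.39 log units; beyond the scatter) gave no hint of: adding methoxy groups on this side of the molecule does not push the number in one direction across compound 2, compound 3 and compound 4. With this methoxy group in place, methyl in place of hydrogen on the amide-type nitrogen does not weaken the result, and a 2.2-fold lower number from compound 1 to compound 4 (0.34 log units; beyond the scatter) runs towards a stronger inhibitor, which compound 1 alone could not show. The first of these steps is only a floor, as compound 3 stands at a limit: the limit of > 25000 nM in this assay, at which 1 of the 4 values shown sits.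

The compounds shown leave open whether a hydroxyl, a fluorine or an ethoxy group on this aromatic carbon would keep the number low. They also leave open whether an ethyl group or a longer chain on the amide-type nitrogen would go the same way as methyl.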